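Replacing the 3-chlorophenyl group of compound 3

The source may hold more compounds than are shown below. What is called first, only, known or untested is meant among the compounds shown, and "the series" means these compounds.

Measured in a functional assay on HCT-116 cells (Homo sapiens) for antiproliferative activity, read by MTT assay, with a stated time of 72 h; on this read-out lower numbers stand for stronger inhibition and higher numbers for weaker inhibition:
Compound 1 `O=C(CCc1cccc2c1B(O)OC2)Nc1cccc(-c2ccccc2)c1`: 890 nM
Compound 2 `O=C(CCc1cccc2c1B(O)OC2)Nc1cccc(-c2cccc(F)c2)c1`: 460 nM
Compound 3 `O=C(CCc1cccc2c1B(O)OC2)Nc1cccc(-c2cccc(Cl)c2)c1`: 350 nM

Compound 3 shares the low end of this small set with one other compound: a 1.3-fold lower number from compound 2 to compound 3 (0.12 log units; within the scatter). Compound 4 `CSc1ccc(-c2cccc(NC(=O)CCc3cccc4c3B(O)OC4)c2)cc1` carries 4-(methylsulfanyl)phenyl in place of 3-chlorophenyl on an aromatic carbon. The nearest evidence is the replacement of hydrogen by fluoro or chloro, a 1.9-fold lower number from compound 1 to compound 2 (0.29 log units; within the scatter) and a 2.5-fold lower number from compound 1 to compound 3 (0.41 log units; beyond the scatter), and both steps are small. Going by the values given here, no measured compound carries the entering group, so no step beyond the scatter is expected in this assay, in either direction. The expected step is a 1.2-fold higher number from compound 3 to compound 4 (0.08 log units; within the scatter). The estimated value for compound 4 is 420 nM, with an expected range of 160 nM to 1100 nM.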

Compound 4, half-maximal inhibitory concentration: 180 nM
Beside the measured number, compound 4's estimate is 2.3-fold (0.37 log units) above it, within the range that was stated.
By their numbers in this assay, from the lowest: compounds 4, 3, 2 and 1 (each within the scatter of the next, the first and the last beyond it).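

The 4-(methylsulfanyl)phenyl group serves as well as 3-chlorophenyl in this assay (a 1.9-fold lower number from compound 3 to compound 4 (0.29 log units; within the scatter)), so this position is not limited to the halogen-bearing rings seen so far. It also stands clear of 3-fluorophenyl (a 2.6-fold lower number from compound 2 to compound 4 (0.41 log units; beyond the scatter)), which the chloro compound did not do. Its step from the unsubstituted phenyl (a 4.9-fold lower number from compound 1 to compound 4 (0.69 log units; beyond the scatter)) is the largest in this set. On these data alone, how a methoxy group or an amine would fare in place of methylsulfanyl remains open. Nothing given here explains the size of these steps.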